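Replacing the hydroxyphenyl amide with a cyclohexyl amide

A few compounds are considered here, and "the series" means these few. Any claim that something is new, unique, unknown or untested is made for them only; others in the source may bear on it.

The four compounds share one core, a hydroxyamino-substituted phenylpyranone carrying a carboxamide. Compound 1 `COc1ccccc1NC(=O)c1c(NO)cc(-c2ccccc2)oc1=O` and compound 2 `CCOc1ccccc1NC(=O)c1c(NO)cc(-c2ccccc2)oc1=O` bear a methoxyphenyl or an ethoxyphenyl on the amide nitrogen, while compound 3 `O=C(Nc1ccccc1O)c1c(NO)cc(-c2ccccc2)oc1=O` carries a hydroxyphenyl there. In an ADME assay on Huh-7 cells (Homo sapiens) for cytotoxicity, with a stated time of 3 days (on this read-out higher numbers stand for lower toxicity in this test and lower numbers for higher toxicity in this test), compound 1 gives only a limit of the assay, > 20000 nM. Compound 2 likewise reaches only a limit, > 20000 nM. Among the measured compounds shown here, compound 3 is the single compound with a number, 14000 nM, and the limit of > 20000 nM in this assay, at which 2 of the 3 values shown sit, sets the position of the other two. The step of an at least 1.4-fold lower number from compound 1 to compound 3 (0.15 log units; that floor lies within the scatter) and the step of an at least 1.4-fold lower number from compound 2 to compound 3 (0.15 log units; that floor lies within the scatter) are both floors that lie within the scatter, and the step that the two limits leave unreadable from compound 1 to compound 2 cannot be read.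

Compound 4 `O=C(NC1CCCCC1)c1c(NO)cc(-c2ccccc2)oc1=O` differs from compound 3 by cyclohexyl in place of 2-hydroxyphenyl on an amide-type nitrogen. For the measured compounds named here, none of the measured steps concerns the amide nitrogen, so no measured step bears directly on this change. The author expects no step beyond the scatter, a 1.4-fold higher number from compound 3 to compound 4 (0.15 log units; within the scatter), and estimates for compound 4 a value of 20000 nM, between 8000 nM and 50000 nM, with a fair chance that this assay again reports only a limit.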

Compound 4, half-maximal cytotoxic concentration: 10500 nM
The estimate for compound 4 lay 1.9-fold (0.28 log units) above the measured number, and the stated range covers the measured number.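

The change from 2-hydroxyphenyl to cyclohexyl on the amide-type nitrogen gives a 1.3-fold lower number from compound 3 to compound 4 (0.12 log units; within the scatter) in this assay, so this position now has a step of its own, and that step is not separated from the scatter. A number in this assay is also no longer confined to compound 3, since compound 4 gives one with neither the aromatic ring nor the hydroxyl of 2-hydroxyphenyl. Against the 2-ethoxyphenyl and 2-methoxyphenyl amides there are only floors, an at least 1.9-fold lower number from compound 2 to compound 4 (0.27 log units; that floor lies within the scatter) and an at least 1.9-fold lower number from compound 1 to compound 4 (0.27 log units; that floor lies within the scatter), and neither shows a real difference, because each rests on a limit: the limit of > 20000 nM in this assay, at which 2 of the 4 values shown sit.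

On these data alone, whether an amine, a carboxylic acid or a longer chain on the amide nitrogen would give a step beyond the scatter remains open. The compounds shown also leave open what a change to the hydroxyamino group or the phenyl on the shared core would do.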